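From compound 3 to compound 4: an expected value

The source may report more compounds than this note shows. Statements on the series, on what has been measured and on what is new or still open speak of the compounds shown alone.

Compound 1 `COC(=O)c1cc(C2=C(c3cc(OC)c(OC)c(OC)c3)C(=O)CC2O[SiH2]C(C)(C)C)ccc1OC`: > 100 ug/mL (a limit)
Compound 2 `COCOc1cc(C2=C(c3cc(OC)c(OC)c(OC)c3)C(=O)CC2O[SiH2]C(C)(C)C)ccc1OC`: 50 ug/mL
Compound 3 `COc1cc(C2=C(c3cc(C)c(OC)c(C)c3)C(O[SiH2]C(C)(C)C)CC2=O)cc(OC)c1OC`: "not determined" (no result reported)

All three compounds were examined in an ADME assay on MIA PaCa-2 cells (Homo sapiens) for cytotoxicity, read by MTT assay, with a stated time of 72 h; on this read-out higher numbers stand for weaker inhibition and lower numbers for stronger inhibition. Compound 1 gives > 100 ug/mL, which is a limit of the assay and not a number. Compound 2 gives 50 ug/mL. Compound 3 has no number on this scale, so it offers no starting value.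

Compound 4 `COc1ccc(C2=C(c3cc(OC)c(OC)c(OC)c3)C(=O)CC2O[SiH2]C(C)(C)C)cc1O` arises from compound 3 through (3-hydroxy-4-methoxyphenyl in place of 4-methoxy-3,5-dimethylphenyl on a double-bonded ring carbon). Within the data shown here, no measured step covers this change. The nearest evidence is an at least 2.0-fold lower number from compound 1 to compound 2 (0.30 log units; that floor lies within the scatter). That step places methoxymethoxy in place of methoxycarbonyl on an aromatic carbon, and compound 4 differs from compound 2 only in that same group. As that step does not get clear of the scatter, it sets no size or direction for the new group. The expectation in this assay is therefore that compound 4 stays close to compound 2, which gives 50 ug/mL, with wide uncertainty. Compound 4 is estimated at 40 ug/mL, with an expected range from 8 ug/mL to 100 ug/mL.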

Compound 4, half-maximal inhibitory concentration: 55 ug/mL
Estimate against measurement, compound 4: 1.4-fold (0.14 log units) below, and the stated range covers the measured number.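

Among these compounds, compound 4 offers the first look at a free hydroxy on this aromatic ring, and in this assay the change of hydrogen for methoxymethyl on that oxygen gives a 1.1-fold higher number from compound 2 to compound 4 (0.04 log units; within the scatter). Capped or free, that oxygen therefore gives two readings that cannot be told apart here. Hydroxy in place of methoxycarbonyl gives an at least 1.8-fold lower number from compound 1 to compound 4 (0.25 log units; that floor lies within the scatter), and this step cannot set an order between the two groups, because it starts from a value that is a limit and not a number: the limit of > 100 ug/mL in this assay, at which 1 of the 4 values shown sits.

The compounds shown leave open whether an amine or a longer alkoxy chain on the same aromatic carbon would give a reading clearly apart from these. They also leave open what a carboxylic acid would give in place of the methoxycarbonyl.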